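The source may hold more compounds than are shown below. What is called first, only, known or untested is meant among the compounds shown, and "the series" means these compounds.

Measured compounds in an assay on isolated protein for inhibition of Maltase-glucoamylase (Homo sapiens), with a stated time of 15 min; a lower number here means a stronger inhibitor, a higher number a weaker inhibitor:
- compound 1, `COc1ccc(O)c(/C=N/NC(=O)c2ccc(-c3nc4ccccc4s3)cc2)c1`: 6500 nM
- compound 2, `COc1cc(/C=N/NC(=O)c2ccc(-c3nc4ccccc4s3)cc2)cc(OC)c1`: 16200 nM
- compound 3, `COc1cccc(/C=N/NC(=O)c2ccc(-c3nc4ccccc4s3)cc2)c1`: 11100 nM

Compound 3 gives the second highest of the three numbers. Its nearest neighbour is compound 2, at a 1.5-fold lower number from compound 2 to compound 3 (0.16 log units; within the scatter), and the furthest is compound 1, at a 1.7-fold higher number from compound 1 to compound 3 (0.23 log units; within the scatter); both gaps sit inside the scatter, so compound 3 cannot be separated from either. Among the compounds with values here, the only step that clears the scatter is a 2.5-fold higher number from compound 1 to compound 2 (0.40 log units; beyond the scatter), which compares two substituted rings with each other rather than with compound 3.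

Compound 4, `O=C(N/N=C/c1ccncc1)c1ccc(-c2nc3ccccc3s2)cc1`, is not yet measured. The change from compound 3 is pyridin-4-yl in place of 3-methoxyphenyl on a carbon with a double bond to nitrogen. The measured steps touch only single substituents on the phenyl ring: removing a methoxy, a 1.5-fold lower number from compound 2 to compound 3 (0.16 log units; within the scatter), and removing a hydroxy, a 1.7-fold higher number from compound 1 to compound 3 (0.23 log units; within the scatter), each stayed within the scatter. Within the data shown here, no measured pair exchanges the whole ring for a heteroaryl ring, so the present step is not covered directly. With nothing to point in either direction, no step beyond the scatter is expected, but the range is set wider than for the substituent changes already seen.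

Compound 4 is therefore expected at about 11000 nM in this assay, with a range of 4000 nM to 30000 nM. This estimate means an expected step of a 1.0-fold lower number from compound 3 to compound 4 (0.00 log units; within the scatter).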

Compound 4, half-maximal inhibitory concentration: "not active" (no number reported)
The entry for compound 4 holds no number; there is nothing to compare the estimate with.
By their numbers in this assay, from the lowest: compounds 1, 3 and 2 (each within the scatter of the next, the first and the last beyond it).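

In this assay, within the data shown here, compound 4 is reported as "not active" with no number, so no step from compound 3 to compound 4 can be read. The compounds shown leave open how far pyridin-4-yl in place of 3-methoxyphenyl moves the number, and whether other heteroaryl rings would behave alike. Nothing available accounts for this result.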